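From Trifluoromethyl to Nitro on an Aromatic Carbon

The compounds below may be only part of what the source reports. "The series", "measured", "known", "first", "only" and "open" are said of these compounds alone.

- Compound 1 `CCOC(=O)N1C(=S)N=C(C)/C(=C(/O)OCC)C1c1cccc([N+](=O)[O-])c1`: 17 nM
- Compound 2 `CCO/C(O)=C1\C(C)=NC(=S)N(C(=O)OC2CCN(Cc3ccccc3)CC2)C1c1ccccc1C(F)(F)F`: 9 nM
- Compound 3 `CC1=NC(=S)N(C(=O)OC2CCN(Cc3ccccc3)CC2)C(c2ccccc2C(F)(F)F)/C1=C(\O)OC(C)C`: 5 nM

In a functional assay (aorta) for inhibition, with Oryctolagus cuniculus as the target (on this read-out higher numbers stand for weaker inhibition and lower numbers for stronger inhibition), compound 3 gives 5 nM, a number within the scatter of compound 2 and lower than that of compound 1. Compound 4 `CC1=NC(=S)N(C(=O)OC2CCN(Cc3ccccc3)CC2)C(c2ccccc2[N+](=O)[O-])/C1=C(\O)OC(C)C` carries nitro in place of trifluoromethyl on an aromatic carbon. Within the data shown here, the one measured step, a 1.8-fold lower number from compound 2 to compound 3 (0.26 log units; within the scatter), lies elsewhere in the molecule, so no measured step makes this exchange. Compound 1 also carries nitro, but it differs from compound 3 in other places too, so it offers no direct guide. Starting from compound 3 at 5 nM, no change beyond the scatter is expected, and the estimated step is a 1.4-fold higher number from compound 3 to compound 4 (0.15 log units; within the scatter). For compound 4 the expected value is 7 nM, within an estimated range of 2.5 nM to 20 nM.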

Compound 4, half-maximal inhibitory concentration: 2 nM
Beside the measured number, compound 4's estimate is 3.5-fold (0.54 log units) above it, and the stated range ends above it.
By their numbers in this assay, from the lowest: compound 4; then compounds 3, 2 and 1 (each within the scatter of the next, the first and the last beyond it).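

In this assay, nitro in place of trifluoromethyl on this aromatic carbon, ortho to a large group, gives a 2.5-fold lower number from compound 3 to compound 4 (0.40 log units; beyond the scatter) and so lies beyond the scatter. The only earlier step, a 1.8-fold lower number from compound 2 to compound 3 (0.26 log units; within the scatter) at a different place in the molecule, stayed within the scatter, so this aromatic carbon is the one place shown where a single exchange moves the number beyond it. Nitro is thus tolerated here, and the inhibition is at least retained.

On these data alone, how a nitrile or a methoxy group on this carbon would compare stays open. Nothing shown bears on the reason for this step.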